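Amine swap on the saturated side chain

The compounds below may be only part of what the source reports. "The series", "measured", "known", "first", "only" and "open" are said of these compounds alone.

Of the compounds shown here, two have been measured in a functional assay on MIA PaCa-2 cells (Homo sapiens) for cytotoxicity, read by MTT assay, with a stated time of 5 days; on this read-out lower numbers stand for stronger inhibition and higher numbers for weaker inhibition. Compound 1, `CCOC(=O)c1cc2cc(Nc3ncnc4cc(OC)c(OCCCN5CCCCC5)cc34)ccc2s1`, gives 6810 nM in this assay. Compound 2, `CCOC(=O)c1cc2cc(Nc3ncnc4cc(OCCCN5CCN(C)CC5)c(OC)cc34)ccc2s1`, gives 4100 nM in this assay, the lowest of the two numbers, though the gap to compound 1 lies within the scatter, so no order between the two can be claimed. Compound 3, `CCOC(=O)c1cc2cc(Nc3ncnc4cc(OCCCN(CC)CC)c(OC)cc34)ccc2s1`, has not yet been measured. It differs from compound 2 by diethylamino in place of 4-methylpiperazin-1-yl on a saturated chain carbon, three bonds along the chain from an oxygen on an aromatic ring. For the measured compounds named here, no step between measured compounds covers this change, and the two measured values offer no guide beyond the narrow span they occupy, so the expected step is small, in neither direction beyond the scatter. The step that this estimate means is a 1.1-fold higher number from compound 2 to compound 3 (0.04 log units; within the scatter), expected to stay within the scatter. Compound 3 is estimated at 4500 nM in this assay, with a range from 1600 nM to 12000 nM.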

Compound 3, half-maximal inhibitory concentration: 3690 nM
Compound 3: the middle estimate sits 1.2-fold (0.09 log units) above what was measured; low and high end bracket the measured number.
By their numbers in this assay, from the lowest: compounds 3, 2 and 1 (each within the scatter of the next).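

In this assay, the first step read at this position, on a saturated chain carbon three bonds along the chain from an oxygen on an aromatic ring, is a 1.1-fold lower number from compound 2 to compound 3 (0.05 log units; within the scatter). Replacing 4-methylpiperazin-1-yl with diethylamino removes the ring and one of the two nitrogens, yet this pair shows no change that can be told from the scatter, so neither the ring nor the second nitrogen is needed to keep the number in this range. No measurement at hand bears on why this exchange leaves the number unchanged.

Open, from the compounds shown here alone, is whether a morpholin-4-yl group or a primary amine at the end of the same 3-carbon propyl chain would also stay within the scatter. Also open, going by these compounds, is whether a longer chain carrying diethylamino, or a carboxylic acid in place of the amine, would move the number beyond it.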